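The source may report more compounds than this note shows. Statements on the series, on what has been measured and on what is new or still open speak of the compounds shown alone.

Working notes on the amide-aryl variants of the shared core.

Two compounds carry a measurement in an assay on isolated protein for inhibition of histone deacetylase 4 (Homo sapiens), with a stated time of 1 h; on this read-out higher numbers stand for weaker inhibition and lower numbers for stronger inhibition. Compound 1 `O=C(COc1ccc2cc(/C=C3/SC(=O)NC3=O)ccc2c1)Nc1ccc([N+](=O)[O-])cc1` gives 1700 nM in this assay. Compound 2 `O=C(COc1ccc2cc(/C=C3/SC(=O)NC3=O)ccc2c1)Nc1ccc(Cl)c(Cl)c1`, which differs only in the group on the amide-type nitrogen, gives 5500 nM in this assay. Going by the values given here, the one step measured so far, a 3.2-fold higher number from compound 1 to compound 2 (0.51 log units; beyond the scatter), is the whole of the record on this position, and on it compound 2 stands with the higher of the two numbers.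

Compound 3 `O=C(COc1ccc2cc(/C=C3/SC(=O)NC3=O)ccc2c1)Nc1cc(Cl)cc(C(F)(F)F)c1` is not yet measured. It differs from compound 2 by 3-chloro-5-(trifluoromethyl)phenyl in place of 3,4-dichlorophenyl on an amide-type nitrogen. Among the compounds with values here, no measured step exchanges one chlorine-bearing aryl for another on the amide-type nitrogen, so the only bearing comes from the exchange of the nitro-bearing aryl for the dichloro-bearing one, which moved the number by a 3.2-fold higher number from compound 1 to compound 2 (0.51 log units; beyond the scatter); that step is of modest size and gives no direct reading on the present change. The expected step in this assay is therefore no change at the digits printed from compound 2 to compound 3 (within the scatter), not beyond the scatter in either direction. For compound 3 the estimate in this assay is 5500 nM, with a range from 1800 nM to 17000 nM.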

Compound 3, half-maximal inhibitory concentration: 4000 nM
Estimate against measurement, compound 3: 1.4-fold (0.14 log units) above; measured number inside the range.
By their numbers in this assay, from the lowest: compound 1; then compounds 3 and 2 (each within the scatter of the next).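

In this assay, exchanging one chlorine-bearing aryl for another on the amide-type nitrogen gives a 1.4-fold lower number from compound 2 to compound 3 (0.14 log units; within the scatter) and so does not separate 3-chloro-5-(trifluoromethyl)phenyl from 3,4-dichlorophenyl, although the entering group has more heavy atoms and a different set of substituents. The comparison with the nitro-bearing aryl gives a 2.4-fold higher number from compound 1 to compound 3 (0.37 log units; beyond the scatter) and so shows that the gap first seen with compound 2 is not confined to a single chlorine-bearing aryl, with compound 1 holding the lowest number of the three and both of its steps lying beyond the scatter, though this reading rests on these three compounds alone. No measured evidence is available that bears on what lies behind these steps.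

The compounds shown leave open whether the gap to compound 1 belongs to the nitro group itself or would also appear with an aryl carrying a nitrile, an amine or a carboxylic acid in its place. They also leave open how far the number at this position depends on an aryl at all, as a cyclohexyl group or a longer alkyl chain on the amide-type nitrogen would show.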